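The source may hold more compounds than are shown below. What is called first, only, known or untested is meant among the compounds shown, and "the series" means these compounds.

Compound 1, `CCCCCCCCCCCCCCCC(=O)Nc1cccc2c1OC(C)(C)C2`: 890 nM
Compound 2, `CCCCCCCCCCC1(C(=O)Nc2cccc3c2OC(C)(C)C3)CCCC1`: 500 nM
Compound 3, `CCCCCCCCCCCCC(C)(C)C(=O)Nc1c(C)cc(C)c2c1OC(C)(C)C2`: 33 nM

Three amides built on the shared core have been tested in an assay for inhibition of acyl-CoA:cholesterol acyltransferase (Oryctolagus cuniculus), using microsomes; on this read-out higher numbers stand for weaker inhibition and lower numbers for stronger inhibition. Compound 3 stands lowest of the three numbers, with 33 nM. The nearest of the others is compound 2 at 500 nM, and the furthest is compound 1 at 890 nM; both gaps to compound 3 lie beyond the scatter of this assay, so compound 3 is the strongest inhibitor among the three measured.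

Compound 4, `Cc1cc(C)c(NC(=O)C(C)(C)CCCCOc2ccc(Cl)cc2)c2c1CC(C)(C)O2`, has not yet been measured. It differs from compound 3 in a single place: 4-chlorophenoxy in place of octyl on a saturated chain carbon, five bonds along the chain from a carbonyl carbon. The amide, the core and the branching next to the carbonyl carbon are carried over unchanged. Within the data shown here, no measured pair in this set shows what such an exchange at the far end of the chain does, so the expectation rests on compound 3 alone. The account expects compound 4 to lose some ground in this assay, a step of a 2.7-fold higher number from compound 3 to compound 4 (0.44 log units; beyond the scatter) toward a higher number, modest and possibly no more than the scatter. The estimate for compound 4 is therefore 90 nM, with a range from 30 nM to 300 nM.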

Compound 4, half-maximal inhibitory concentration: 330 nM
Beside the measured number, compound 4's estimate is 3.7-fold (0.56 log units) below it; the measured number lies above the stated range.
By their numbers in this assay, from the lowest: compound 3; then compounds 4, 2 and 1 (each within the scatter of the next, the first and the last beyond it).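

In this assay, the far end of the chain turns out to matter: putting 4-chlorophenoxy in place of octyl on a saturated chain carbon, five bonds along the chain from a carbonyl carbon, gives a 10-fold higher number from compound 3 to compound 4 (1.00 log units; beyond the scatter), a step beyond the scatter. The group that leaves and the group that enters hold the same count of heavy atoms, so the step comes with no change in that count, and what differs is the aromatic ring, the oxygen and the chlorine that enter. The earlier compounds offered no pair that isolated this position, and nothing given here bears on what lies behind the rise, so the step stands as an observation without a cause.

The compounds shown do not separate the contributions of the ring, the oxygen and the chlorine, which a plain phenoxy group or a 4-chlorophenyl group joined directly to the chain could begin to do. They also leave open how a carboxylic acid or an amine at the end of the chain would read out, and whether the same exchange would cost as much on the amides that carry other substitution.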